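The source may hold more compounds than are shown below. What is called first, only, known or untested is meant among the compounds shown, and "the series" means these compounds.

Working notes on the series in an ADME assay on McCoy cells (Mus musculus) for antiproliferative activity, read by sulforhodamine B assay, with a stated time of 48 h; a higher number here means a weaker inhibitor, a lower number a stronger inhibitor.

Compound 2 `CC(C)(C)OC(=O)NCCCC[C@H]1N=C2C[C@H]3C[C@H](C3(C)C)[C@@]2(C)OC1=O` is the reference. In this assay compound 2 gives only a limit, > 1300000 nM, not a number. Compound 1 `CC(C)(C)OC(=O)NCCC[C@@H]1N=C2C[C@@H]3C[C@@H](C3(C)C)[C@]2(C)OC1=O` likewise sits at a limit in this assay, > 1200000 nM. Compound 3 `CC1(C)[C@@H]2CC3=N[C@@H](CCC(=O)O)C(=O)O[C@@]3(C)[C@H]1C2` also returns only a limit in this assay, > 1200000 nM. Among the measured compounds shown here, no measured value in the set is a number; all three are limits, as summarised by the limit of > 1200000 nM in this assay, at which 2 of the 3 values shown sit, and (the limit of > 1300000 nM in this assay, at which 1 of the 3 values shown sits), so no step between measured compounds can be placed, and compound 2 cannot be ranked against compound 1 or compound 3.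

Compound 4 `CC(C)(C)OC(=O)NCCC[C@H]1N=C2C[C@H]3C[C@H](C3(C)C)[C@@]2(C)OC1=O` differs from compound 2 by (tert-butoxycarbonyl)amino in place of ((tert-butoxycarbonyl)amino)methyl on a saturated chain carbon, three bonds along the chain from a saturated ring carbon. For the measured compounds named here, no measured step gives a size for this change, and none of the measured compounds shows a number in this assay, so no step beyond the scatter is expected from compound 2 to compound 4; the estimated step is a step that the limit leaves unreadable from compound 2 to compound 4.

The expected value for compound 4 in this assay is 1500000 nM, in the range 800000 nM to 4000000 nM, and most likely it is again reported only as a limit.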

Compound 4, half-maximal inhibitory concentration: > 1500000 nM
Compound 4: no number, only a limit; the forecaster's own chance of this, stated with the estimate: 90%; the middle value lies on the limit itself.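

In this assay, among the compounds shown here, compound 4 gives only a limit, > 1500000 nM, so no step to it from compound 1 or compound 2 can be read. Going by these compounds, whether (tert-butoxycarbonyl)amino in place of ((tert-butoxycarbonyl)amino)methyl, or the mirror-image configuration of compound 1 and compound 4, changes activity in this assay stays open.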